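From cyclopentyl to 2-methoxyphenyl on an amine nitrogen

The source may hold more compounds than are shown below. What is called first, only, known or untested is meant among the compounds shown, and "the series" means these compounds.

Values in a functional assay on HeLa cells (Homo sapiens) for inhibition, read by sulforhodamine B assay (a higher number here means a weaker inhibitor, a lower number a stronger inhibitor), are as follows:
- Compound 1 `CCCc1ccc(NC2=CC(=O)c3nc4n(c3C2=O)[C@H]2OC[C@@H](O)[C@H]2OC4)cc1` gives 4990 nM
- Compound 2 `O=C1C(NC2CCCC2)=CC(=O)c2c1nc1n2[C@H]2OC[C@@H](O)[C@H]2OC1` gives only a limit, not a number: > 16000 nM
- Compound 3 `O=C1C=C(Nc2ccccc2F)C(=O)c2c1nc1n2[C@H]2OC[C@@H](O)[C@H]2OC1` gives 5120 nM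

Compound 2 therefore stands at the limit of > 16000 nM in this assay, at which 1 of the 3 values shown sits, and has no exact value. Compound 4 `COc1ccccc1NC1=CC(=O)c2c(nc3n2[C@H]2OC[C@@H](O)[C@H]2OC3)C1=O` differs from it thus: 2-methoxyphenyl in place of cyclopentyl on an amine nitrogen. The measured step that bears on this is a 1.0-fold higher number from compound 1 to compound 3 (0.01 log units; within the scatter), which exchanges one substituted phenyl for another. Compound 4 also carries a substituted phenyl, so it is expected to sit close to compound 3 at 5120 nM in this assay. The expected change is an at least 2.9-fold lower number from compound 2 to compound 4 (0.46 log units; beyond the scatter), towards a lower number and so a stronger inhibitor. For compound 4 the estimated value is 5500 nM, with an expected range from 2500 nM to 13000 nM.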

Compound 4, half-maximal inhibitory concentration: 7460 nM
Compound 4: middle estimate off by 1.4-fold (0.13 log units), on the low side; the range from low to high includes it.
By their numbers in this assay, from the lowest: compounds 1, 3 and 4 (each within the scatter of the next). At a limit, above all of these: compound 2.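

In this assay, the change from a non-aromatic ring to an aromatic ring on the amine nitrogen gives an at least 2.1-fold lower number from compound 2 to compound 4 (0.33 log units; beyond the scatter). Compound 2 has only a limit of the assay, not a number, so this step gives a minimum size: the limit of > 16000 nM in this assay, at which 1 of the 4 values shown sits.

Compound 1, compound 3 and compound 4 all lie within the scatter of each other, so their three substituted phenyl groups read alike here, while only compound 2, with its cyclopentyl, sits at a limit.

Cyclopentyl is the only non-aromatic group shown, so whether the aromatic ring itself is what counts remains open. A cyclohexyl or a benzyl group on the same amine nitrogen would bear on this.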